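Leaving the 4-cyanophenyl group of compound 3

The compounds below may be only part of what the source reports. "The series", "measured", "known", "first", "only" and "open" are said of these compounds alone.

In an in vitro ADME assay on microsomes from liver (Homo sapiens) for pharmacokinetics, read by LC-MS, with a stated time of 10 min, tested at 1 uM (a lower number here means slower removal, a higher number faster removal of the compound), compound 3 `CN1C[C@H](C(=O)Nc2ccc(C#N)cc2)[C@@H](c2ccc(/C=C/C(=O)Nc3ccccc3N)cc2)C1` gives the lowest of the three measured numbers at 1 mL/min/kg, against compound 1 `CN1C[C@H](C(=O)Nc2ccc(F)cc2)[C@@H](c2ccc(/C=C/C(=O)Nc3ccccc3N)cc2)C1` at 5 mL/min/kg and compound 2 `Cc1ccc(NC(=O)[C@H]2CN(C)C[C@@H]2c2ccc(/C=C/C(=O)Nc3ccccc3N)cc2)cc1` at 15 mL/min/kg. Compound 4 `CN1C[C@H](C(=O)Nc2cccc(Cl)c2)[C@@H](c2ccc(/C=C/C(=O)Nc3ccccc3N)cc2)C1` has 3-chlorophenyl in place of 4-cyanophenyl on an amide-type nitrogen. Within the data shown here, two measured steps bear on this change. Cyano in place of fluoro gave a modest 5.0-fold lower number from compound 1 to compound 3 (0.70 log units; beyond the scatter), and cyano in place of methyl gave a large 15-fold lower number from compound 2 to compound 3 (1.18 log units; beyond the scatter). Among the measured compounds shown here, no measured compound carries the 3-chlorophenyl group, so this comparison is indirect. Read in reverse, both steps point to a modest-to-large rise on losing cyano. The expected change is an 8.0-fold higher number from compound 3 to compound 4 (0.90 log units; beyond the scatter). Compound 4 is estimated at 8 mL/min/kg, within an expected range from 3 mL/min/kg to 22 mL/min/kg.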

Compound 4, clearance: 7 mL/min/kg
Estimate against measurement, compound 4: 1.1-fold (0.06 log units) above, within the range that was stated.
By their numbers in this assay, from the lowest: compound 3; then compounds 1 and 4 (each within the scatter of the next); then compound 2.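

In this assay the lowest number of the four stays with 4-cyanophenyl on the amide-type nitrogen, since 3-chlorophenyl in its place gives a 7.0-fold higher number from compound 3 to compound 4 (0.85 log units; beyond the scatter). Replacing 4-methylphenyl with 3-chlorophenyl gives a 2.1-fold lower number from compound 2 to compound 4 (0.33 log units; beyond the scatter), whereas replacing 4-fluorophenyl with it gives a 1.4-fold higher number from compound 1 to compound 4 (0.15 log units; within the scatter). Nothing available explains these differences.

The compounds shown do not separate the chlorine from its place on the ring, as neither 4-chlorophenyl nor 3-cyanophenyl is among them. Going by these compounds, how a 4-methoxyphenyl or 4-aminophenyl group would read at this nitrogen also stays open.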